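Removing the methoxy group from compound 1

This account rests on a few compounds, and the source may have more. Where it says the series, first, only, none or still open, it means among the compounds named here.

Two compounds of the series have been taken through a functional assay on cells (Leukemia cell, Homo sapiens) for inhibition; on this read-out lower numbers stand for stronger inhibition of growth and higher numbers for weaker inhibition of growth. Going by the values given here, compound 1 `COc1ccc(-c2nc3sc(Cc4ccccc4)nn3c2SC#N)cc1` gives 72400 nM in this assay, the higher of the two numbers so far, while compound 2 `O=Cc1c(-c2ccc(F)cc2)nc2sc(CCC3CCCCC3)nn12` gives 70800 nM; the two values lie within the scatter of each other, so nothing can be read from their order. Both sit in the weak range of the read-out.

Compound 3 `N#CSc1c(-c2ccccc2)nc2sc(Cc3ccccc3)nn12` is the next case, still to be measured in this assay. It differs from compound 1 in one place: hydrogen in place of methoxy on an aromatic carbon, on an aromatic carbon of a six-membered aromatic ring of carbon only. Among the compounds with values here, no step between measured compounds is in hand to calibrate this change; the only measured pair, compound 1 and compound 2, differs in several places at once and shows no gap beyond the scatter.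

On that basis the change is expected to amount to a 1.1-fold higher number from compound 1 to compound 3 (0.04 log units; within the scatter), no more than the scatter in either direction. Compound 3 is accordingly estimated at 80000 nM, with a range from 30000 nM to 200000 nM.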

Compound 3, concentration for total growth inhibition: 57500 nM
Compound 3: the middle estimate sits 1.4-fold (0.14 log units) above what was measured; measured number inside the range.
By their numbers in this assay, from the lowest: compounds 3, 2 and 1 (each within the scatter of the next).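

In this assay, going by these compounds alone, the step at this position gives a first direct reading of the change from 4-methoxyphenyl to phenyl: hydrogen in place of methoxy on an aromatic carbon gives a 1.3-fold lower number from compound 1 to compound 3 (0.10 log units; within the scatter), which lies within the scatter. The methoxy group, para to a large group on a six-membered aromatic ring of carbon only, can therefore be removed without a change that this read-out can distinguish, and compound 3 stays in the weak range seen for compound 1. Nothing available on these compounds bears on the reason for so small a step.

From the compounds shown here alone, it remains open how an amine, a carboxylic acid or a longer chain such as butoxy would read at this place, so one step cannot show whether the position is generally insensitive or whether only hydrogen and methoxy read alike. Within the data shown here, it is equally open whether the same change would read alike with other groups on the shared core, since compound 2 differs from compound 3 in several places and provides no comparable step.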